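The source may hold more compounds than are shown below. What is called first, only, known or untested is meant among the compounds shown, and "the series" means these compounds.

Among the measured compounds shown here, the three compounds measured so far share one fused core and differ only in the groups attached to it. In a functional assay on HOP-62 cells (Homo sapiens) for cytotoxicity, read by sulforhodamine B assay, with a stated time of 48 h (on this read-out lower numbers stand for stronger inhibition of growth and higher numbers for weaker inhibition of growth), compound 1, `ClCc1ccccc1Cn1cnc2ncnc(Cl)c21`, gives 28800 nM, the highest of the three numbers. Compound 3, `Nc1nc(Cl)c2ncn(Cc3cccc(CCl)c3)c2n1`, gives 20400 nM, which lies within the usual scatter of compound 1, so nothing can be said about an order between those two. Compound 2, `ClCc1cccc(Cn2cnc3nc(Cl)nc(Cl)c32)c1`, gives 3630 nM, a gap from compound 1 that clearly exceeds the scatter; among these three, compound 2 alone carries two chloro groups on its core.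

Compound 4, `ClCc1ccccc1Cn1cnc2nc(Cl)nc(Cl)c21`, is not yet measured. It differs from compound 1 in one place: chloro in place of hydrogen on an aromatic carbon. For the measured compounds named here, no direct pair with exactly this change has been measured, so any expectation must rest on the wider pattern, in which the compound with two chloro groups on the core gives the lowest number. On that basis a step from compound 1 to compound 4 of about a 4.1-fold lower number from compound 1 to compound 4 (0.61 log units; beyond the scatter) is expected, toward stronger inhibition of growth, though compound 3 shows that other groups at the core do not shift the value beyond the scatter. Compound 4 is therefore estimated to give 7000 nM in this assay, with a likely range from 2500 nM to 20000 nM.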

Compound 4, concentration for total growth inhibition: 5490 nM
Compound 4: the middle estimate sits 1.3-fold (0.11 log units) above what was measured; the measured number falls inside the stated range.
By their numbers in this assay, from the lowest: compounds 2 and 4 (each within the scatter of the next); then compounds 3 and 1 (each within the scatter of the next).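

In this assay, a chloro group in place of hydrogen on the aromatic carbon between two ring nitrogen atoms gives a clear change (a 5.2-fold lower number from compound 1 to compound 4 (0.72 log units; beyond the scatter)), toward stronger inhibition of growth and beyond the usual scatter. This is the first pair shown that differs in this one place alone, so the effect of this change can now be read directly rather than inferred from compounds that also differ elsewhere. The data show the size of the step but offer nothing that explains it.

Among the compounds shown here, only a single pair shows this change, so it remains open whether the same swap would give a similar step with the chloromethyl group placed elsewhere on the benzene ring, or in other cell types. As far as these compounds go, it also remains open how other small groups on the same aromatic carbon, such as fluoro, bromo, methyl or methoxy, would compare with chloro, and so whether this step is particular to chloro or would appear with any group replacing hydrogen there.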